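The compounds below may be only part of what the source reports. "The series", "measured", "known", "first", "only" and "open" are said of these compounds alone.

Among the measured compounds shown here, compound 1 `C/C=C/C(=O)Nc1cccc(Oc2nc(Nc3cccc(OC)c3)nc3ccsc23)c1` holds the lower of the two numbers measured so far in a functional assay on MCF7 cells (Homo sapiens) for inhibition, read by MTT assay, with a stated time of 72 h (a higher number here means a weaker inhibitor, a lower number a stronger inhibitor), giving 14600 nM; compound 2 `CC/C=C/C(=O)Nc1cccc(Oc2nc(Nc3cccc(OC)c3)nc3ccsc23)c1` gives 43400 nM in this assay. Compound 3 `C/C=C/C(=O)Nc1cccc(Oc2nc(Nc3cccc(C#N)c3)nc3ccsc23)c1` differs from compound 1 by cyano in place of methoxy on an aromatic carbon. For the measured compounds named here, the only measured step, a 3.0-fold higher number from compound 1 to compound 2 (0.47 log units; beyond the scatter), concerns a methyl on the chain rather than the group changed here, so no measured step bears on this change. With nothing comparable to draw on, the step of no change at the digits printed from compound 1 to compound 3 (within the scatter) is estimated to be small, with no direction beyond the scatter expected. Compound 3 is therefore expected to give 14600 nM, within a range from 4000 nM to 55000 nM.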

Compound 3, half-maximal inhibitory concentration: 33100 nM
Estimate against measurement, compound 3: 2.3-fold (0.36 log units) below; low and high end bracket the measured number.
By their numbers in this assay, from the lowest: compound 1; then compounds 3 and 2 (each within the scatter of the next).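

In this assay, cyano in place of methoxy on this aromatic carbon gives a 2.3-fold higher number from compound 1 to compound 3 (0.36 log units; beyond the scatter), so the change makes the inhibitor modestly weaker. This shows that the number responds to the group on this aromatic ring, and not only to the chain that the earlier pair of compounds varied. Nothing measured here explains the step. With only methoxy and cyano shown at this position, it remains open whether the methoxy is specifically favoured. How a hydrogen, a fluorine, a hydroxyl or an amine would compare is also unknown.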